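The source may report more compounds than this note shows. Statements on the series, on what has been measured and on what is new or still open speak of the compounds shown alone.

Compound 1 `Clc1ccc(CSc2nnc(-c3cnccn3)s2)cc1` gives 4770 nM in a functional assay on SW 1116 cells (Homo sapiens) for antiproliferative activity, read by MTT assay, with a stated time of 48 h; a lower number here means a stronger inhibitor, a higher number a weaker inhibitor.
Compound 2 `Brc1ccc(CSc2nnc(-c3cnccn3)s2)cc1` gives 1470 nM in this assay.
Compound 3 `Clc1ccccc1CSc1nnc(-c2cnccn2)n1-c1ccccc1` gives 18100 nM in this assay.

Compound 1 and compound 2 share one core and differ only by bromo in place of chloro on an aromatic carbon; that single change produced a 3.2-fold lower number from compound 1 to compound 2 (0.51 log units; beyond the scatter). Compound 3 is built on a different core, and the difference between the two cores is not broken down here. Of the three numbers, compound 3 stands highest, and its gaps to compound 1 and compound 2 lie beyond the scatter.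

Compound 4 `Brc1ccccc1CSc1nnc(-c2cnccn2)n1-c1ccccc1`, not yet measured, differs from compound 3 by bromo in place of chloro on an aromatic carbon. This is the same kind of change as that from compound 1 to compound 2, though not the same: there the halogen sits para to a large group, here ortho to a large group. Resting on a 3.2-fold lower number from compound 1 to compound 2 (0.51 log units; beyond the scatter), compound 4 is expected to show a 2.6-fold lower number from compound 3 to compound 4 (0.41 log units; beyond the scatter). Compound 4 is therefore estimated at 7000 nM, between 3500 nM and 14000 nM.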

Compound 4, half-maximal inhibitory concentration: 19400 nM
The estimate for compound 4 lay 2.8-fold (0.44 log units) below the measured number; the whole stated range lies below it.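

In this assay, bromo in place of chloro gave a 1.1-fold higher number from compound 3 to compound 4 (0.03 log units; within the scatter) and so no readable change on the core of compound 3. The step seen on the core of compound 1 therefore did not carry over to this core, and the two steps differ: the same change on two cores in this assay, a 3.2-fold lower number (0.51 log units; beyond the scatter) from compound 1 to compound 2 and a 1.1-fold higher number (0.03 log units; within the scatter) from compound 3 to compound 4, 3.5-fold (0.54 log units) apart, beyond the scatter of two such steps. This does not show what separates them, since the place of the halogen differs along with the core, and one pair per core gives no rule for any further core.

The compounds shown carry only chloro and bromo on the benzyl group, so a methoxy group or an amine there remains open on either core. Also open, going by these compounds, is whether 2-bromobenzyl on the core of compound 1 would follow compound 2 or compound 4.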